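Sulfonyl swap on the shared core: aryl to benzyl

This account rests on a few compounds, and the source may have more. Where it says the series, first, only, none or still open, it means among the compounds named here.

Compound 2 `COc1ccc(-c2cc(=O)c3c(OC)cc(OC)cc3n2S(=O)(=O)c2ccc(Br)cc2)cc1` is seen only as a limit in a functional assay on KOPN-8 cells (Homo sapiens) for antiproliferative activity, with a stated time of 72 h (on this read-out lower numbers stand for an effect already at smaller amounts and higher numbers for an effect only at larger amounts of compound), where compound 2 gives > 86200 nM. Compound 1 `COc1ccc(-c2cc(=O)c3c(OC)cc(OC)cc3n2S(=O)(=O)c2cccc([N+](=O)[O-])c2)cc1` likewise stops at a limit, compound 1 giving > 39600 nM in this assay. Among the compounds with values here, the one measured step, a step that the two limits leave unreadable from compound 1 to compound 2, therefore cannot be read in size; the two limits the limit of > 39600 nM in this assay, at which 1 of the 2 values shown sits, and the limit of > 86200 nM in this assay, at which 1 of the 2 values shown sits, are all the series shows. Compound 3 `COc1ccc(-c2cc(=O)c3c(OC)cc(OC)cc3n2S(=O)(=O)Cc2ccccc2)cc1` differs from compound 2 by benzyl in place of 4-bromophenyl on a sulfonyl sulfur. No readable step bears on this change, so no direction beyond the scatter is expected, and compound 3 is expected to remain at a limit. The estimate for compound 3 is 80000 nM, from 20000 nM to 300000 nM. The expected step is an at least 1.0-fold lower number from compound 2 to compound 3 (0.03 log units; that floor lies within the scatter).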

Compound 3, half-maximal effective concentration: > 34400 nM
Compound 3 gave a limit, no number (the forecaster's own chance of this, stated with the estimate: 75%); the middle value lies beyond the limit too.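

In this assay, within the data shown here, compound 3 gives > 34400 nM, again a limit, so no step among compound 1, compound 2 and compound 3 can be read. On these data alone, whether any sulfonyl group on the shared core gives a readable value in this assay stays open.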